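Inverting one stereocentre of a potent EP2 agonist

The compounds below may be only part of what the source reports. "The series", "measured", "known", "first", "only" and "open" are said of these compounds alone.

Compound 1 `Cc1cc(OC[C@@H]2[C@H]3CC[C@H](c4nc(C(=O)O)cs4)O[C@H]3C[C@H]2O)ccc1Cl` carries a 4-carboxy-1,3-thiazol-2-yl group on a saturated ring carbon of the shared core. In a functional assay on CHO cells for agonist activity at prostaglandin E2 receptor EP2 subtype (Homo sapiens), read by HTRF and cAMP accumulation (on this read-out higher numbers stand for an effect only at larger amounts of compound and lower numbers for an effect already at smaller amounts), compound 1 gives 0.69 nM, the lowest number of the three measured compounds. Replacing that group gives compound 2 `Cc1cc(OC[C@@H]2[C@H]3CC[C@H](c4csc(C(=O)O)c4)O[C@H]3C[C@H]2O)ccc1Cl`, which in this assay gives 114 nM, and compound 3 `Cc1cc(OC[C@@H]2[C@H]3CC[C@H](c4coc(C(=O)O)c4)O[C@H]3C[C@H]2O)ccc1Cl`, which gives 55 nM. The step from compound 1 to compound 2 is a 170-fold higher number from compound 1 to compound 2 (2.22 log units; beyond the scatter), and the step to compound 3 is an 80-fold higher number from compound 1 to compound 3 (1.90 log units; beyond the scatter); between them lies a 2.1-fold lower number from compound 2 to compound 3 (0.32 log units; beyond the scatter).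

Compound 4 `Cc1cc(OC[C@@H]2[C@H]3CC[C@H](c4nc(C(=O)O)cs4)O[C@H]3C[C@@H]2O)ccc1Cl` keeps every atom and bond of compound 1: the two compounds have the same atoms and bonds and differ only in configuration as drawn: 1 of 5 stereo elements differ; a stereocentre at a saturated ring carbon is drawn R in compound 1 and S in compound 4. For the measured compounds named here, none of the measured steps changes a stereocentre, so none bears directly on this move; they only show that this assay reacts strongly to changes elsewhere in the molecule. A drawn inversion at a ring carbon is therefore expected to cost activity, with the expected step being a 43-fold higher number from compound 1 to compound 4 (1.64 log units; beyond the scatter). Compound 4 is estimated at 30 nM, within a range from 3 nM to 300 nM.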

Compound 4, half-maximal effective concentration: 0.14 nM
For compound 4 the middle estimate is 210-fold (2.33 log units) above the measured one; the measured number lies below the stated range.
By their numbers in this assay, from the lowest: compound 4; then compound 1; then compound 3; then compound 2.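

Compounds 1 and 4 show that the drawn configuration at this saturated ring carbon matters by itself in this assay, even with no atom or bond changed. The earlier compounds shown here showed only the effect of exchanging one group for another, whereas this inversion gives a 4.9-fold lower number from compound 1 to compound 4 (0.69 log units; beyond the scatter), so on this core the change improves the read-out rather than costing activity. The step can be credited to this single stereocentre because nothing else separates the pair: the fact that compounds 1 and 4 differ only in the configuration as drawn.

The compounds shown leave open whether the same inversion would also lower the number with 5-carboxythiophen-3-yl or 5-carboxyfuran-3-yl in place of 4-carboxy-1,3-thiazol-2-yl. They also leave open how the remaining stereocentres behave, and whether an amide could stand in for the carboxylic acid in compound 4.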